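From Benzylamine to Phenylsulfonyl Amine on a Shared Core

A few compounds are considered here, and "the series" means these few. Any claim that something is new, unique, unknown or untested is made for them only; others in the source may bear on it.

Of the compounds shown here, three with one shared core have been measured in a functional assay on KB cells (Homo sapiens) for cytotoxicity; on this read-out lower numbers stand for stronger inhibition and higher numbers for weaker inhibition. Compound 1 `COc1ccc(S(=O)(=O)N2CCc3cccc(NC(=O)c4ccc([N+](=O)[O-])cc4)c32)cc1` gives 102 nM. Compound 2 `COc1ccc(S(=O)(=O)N2CCc3cc(Br)cc(NC(=O)c4ccncc4)c32)cc1` gives 91 nM. Compound 3 `COc1ccc(S(=O)(=O)N2CCc3cccc(NCc4ccccc4)c32)cc1` stands apart: its result is not a number but a limit, > 10000 nM, which is the limit of > 10000 nM in this assay, at which 1 of the 3 values shown sits. Compound 3 therefore shows no measurable inhibition in this assay where compound 1 and compound 2 do.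

Compound 4 `COc1ccc(S(=O)(=O)N2CCc3cccc(NS(=O)(=O)c4ccccc4)c32)cc1` is compound 3 with one change: phenylsulfonyl in place of benzyl on a nitrogen on an aromatic ring. In compound 1 and compound 2 the nitrogen on the aromatic ring carries a group with a carbonyl and both are active; in compound 3 it carries a benzyl and is inactive. Among the compounds with values here, the phenylsulfonyl entering compound 4 brings two hydrogen-bond acceptors to that nitrogen, which the benzyl lacked, yet it is not the same group as in compound 1 or compound 2, and no measured step shows what it does. A gain from the limit is expected, of uncertain size, and the expected step is an at least 3.3-fold lower number from compound 3 to compound 4 (0.52 log units; beyond the scatter). Compound 4 is estimated at 3000 nM, within a range of 300 nM to 15000 nM in this assay.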

Compound 4, half-maximal inhibitory concentration: 650 nM
Compound 4: middle estimate off by 4.6-fold (0.66 log units), on the high side, within the range that was stated.
By their numbers in this assay, from the lowest: compounds 2 and 1 (each within the scatter of the next); then compound 4. At a limit, above all of these: compound 3.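

In this assay, the nitrogen on the aromatic ring proves able to carry a group with no carbonyl and still give a measurable number: phenylsulfonyl in place of benzyl gives an at least 15-fold lower number from compound 3 to compound 4 (1.18 log units; beyond the scatter). Both groups hold the same six-membered aromatic ring of carbon only, so the difference lies in what links that ring to the nitrogen, not in the ring itself. From the compounds shown here alone, the full size of the step stays unknown, because compound 3 rests on a limit and not on a number: the limit of > 10000 nM in this assay, at which 1 of the 4 values shown sits.

The compounds shown leave open whether the aromatic ring is needed at all, which a methylsulfonyl group on the same nitrogen would test. They also leave open whether a longer link, such as a benzylsulfonyl group, would keep the gain.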